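This account rests on a few compounds, and the source may have more. Where it says the series, first, only, none or still open, it means among the compounds named here.

Compound 3 `Cc1ccc(C(=O)n2c(-c3cn(-c4ccccc4)nc3-c3ccc(F)cc3)nc3ccccc32)cn1` stands second highest of the three numbers in an ADME assay on HEK-293T cells (Homo sapiens) for cytotoxicity, read by MTT assay, with a stated time of 24 h (a higher number here means that more compound is tolerated, a lower number that less compound is tolerated), where compound 3 gives 137000 nM. Compound 2 `O=C(c1ccncc1)n1c(-c2cn(-c3ccccc3)nc2-c2ccc(F)cc2)nc2ccccc21` gives 151000 nM in this assay, the step being a 1.1-fold lower number from compound 2 to compound 3 (0.04 log units; within the scatter). Compound 1 `Cc1cncc(C(=O)n2c(-c3cn(-c4ccccc4)nc3-c3ccc(F)cc3)nc3ccccc32)c1` gives 119000 nM in this assay, with a 1.2-fold higher number from compound 1 to compound 3 (0.06 log units; within the scatter) and a 1.3-fold higher number from compound 1 to compound 2 (0.10 log units; within the scatter). Compound 4 `Cc1cccc(C(=O)n2c(-c3cn(-c4ccccc4)nc3-c3ccc(F)cc3)nc3ccccc32)c1` differs from compound 3 by 3-methylphenyl in place of 6-methylpyridin-3-yl on a carbonyl carbon. All three steps seen so far on this carbonyl carbon swapped one aryl group for another and stayed within the scatter, so the move to 3-methylphenyl is expected to bring no step beyond the scatter, a 1.0-fold higher number from compound 3 to compound 4 (0.01 log units; within the scatter). Compound 4 is therefore estimated at 140000 nM in this assay, with a range from 70000 nM to 280000 nM.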

Compound 4, half-maximal cytotoxic concentration: 148000 nM
Compound 4: the middle estimate sits 1.1-fold (0.02 log units) below what was measured, and the stated range covers the measured number.
By their numbers in this assay, from the lowest: compounds 1, 3, 4 and 2 (each within the scatter of the next).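

Swapping the pyridine rings on this carbonyl carbon for 3-methylphenyl, a ring of carbon only, leaves this assay flat in all three comparisons (a 1.1-fold higher number from compound 3 to compound 4 (0.03 log units; within the scatter); a 1.0-fold lower number from compound 2 to compound 4 (0.01 log units; within the scatter); a 1.2-fold higher number from compound 1 to compound 4 (0.09 log units; within the scatter)). The ring nitrogen, the one hydrogen-bond acceptor counted in 6-methylpyridin-3-yl, is therefore not needed to keep the number within the scatter of the pyridine compounds. No measurement on hand explains this flatness.

Every group shown here is a six-membered aromatic ring, so a carboxylic acid, a basic amine or a longer alkyl chain on this carbonyl carbon remains open.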